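Cytotoxicity notes on one series and a proposed chloro analogue

The source may report more compounds than this note shows. Statements on the series, on what has been measured and on what is new or still open speak of the compounds shown alone.

Measured so far:
Compound 1 `Cc1ccc(-c2nn(-c3ccccc3)cc2CNc2ccccc2)cc1` gives > 100000 nM in an ADME assay on BHK-21 cells (Mesocricetus auratus) for cytotoxicity, read by MTT assay, with a stated time of 72 h (a lower number here means that less compound is tolerated, a higher number that more compound is tolerated), a limit of the assay.
Compound 2 `Cc1ccc(-c2nn(-c3ccccc3)cc2CNc2ccc(C(F)(F)F)cc2)cc1` gives 88000 nM in this assay.
Compound 3 `Cc1ccc(NCc2cn(-c3ccccc3)nc2-c2ccc(C)cc2)cc1` gives > 100000 nM in this assay, a limit of the assay.

Going by the values given here, compound 2 holds the only plain number; the other two values sit at the limit of > 100000 nM in this assay, at which 2 of the 3 values shown sit. The steps of an at least 1.1-fold lower number from compound 1 to compound 2 (0.05 log units; that floor lies within the scatter) and an at least 1.1-fold higher number from compound 2 to compound 3 (0.05 log units; that floor lies within the scatter) both fall within the scatter. Compound 4 `FC(F)(F)c1ccc(NCc2cn(-c3ccccc3)nc2-c2ccc(Cl)cc2)cc1` differs from compound 2 by chloro in place of methyl on an aromatic carbon. Neither measured step exchanges chloro for methyl, and because an at least 1.1-fold lower number from compound 1 to compound 2 (0.05 log units; that floor lies within the scatter) and an at least 1.1-fold higher number from compound 2 to compound 3 (0.05 log units; that floor lies within the scatter) stayed within the scatter, no step beyond the scatter is expected in this assay. The expected step is a 1.0-fold higher number from compound 2 to compound 4 (0.01 log units; within the scatter). Compound 4 is therefore estimated at 90000 nM, between 45000 nM and 180000 nM, with a real chance that only a limit is returned.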

Compound 4, half-maximal cytotoxic concentration: 17000 nM
Compound 4: middle estimate off by 5.3-fold (0.72 log units), on the high side; the whole stated range lies above it.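

In this assay, going by these compounds alone, 4-methylphenyl to 4-chlorophenyl gives a 5.2-fold lower number from compound 2 to compound 4 (0.71 log units; beyond the scatter), the first step that lies beyond the scatter. This position, para to a large group, therefore responds to the group it carries, which the earlier readable steps, made at another place in the molecule, could not show. On these data alone, whether this step carries over to compounds without trifluoromethyl stays open, and the other values offer no plain number to compare with: the limit of > 100000 nM in this assay, at which 2 of the 4 values shown sit. As far as these compounds go, what a bromo or methoxy group would give at this position is also open.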